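This account rests on a few compounds, and the source may have more. Where it says the series, first, only, none or still open, it means among the compounds named here.

Compound 1 `CN(C)C(=O)N(C)CC#CCN1CCCC1` and compound 2 `CN(C)C(=O)N(C)CC#CCn1ccnc1` share one core. In a functional assay on the whole organism for agonist activity, with Mus musculus as the target (a lower number here means that less compound is needed, a higher number that more compound is needed for the effect), compound 1 gives 1.2 mg/kg, and compound 2 gives 11.8 mg/kg. The change between them, (1H-imidazol-1-yl in place of pyrrolidin-1-yl on a saturated chain carbon bound to a triple-bonded carbon), produces a 9.8-fold higher number from compound 1 to compound 2 (0.99 log units; beyond the scatter). Compound 3 `CC(C#CCN1CCCC1)N1CCN(C)C1=O` rests on a different core; the difference between the two cores is not broken down here. In this assay compound 3 reaches only a limit, > 30 mg/kg. That limit is the limit of > 30 mg/kg in this assay, at which 1 of the 3 values shown sits. Compound 4 `CC(C#CCn1ccnc1)N1CCN(C)C1=O` is not yet measured and differs from compound 3 by the same change, (1H-imidazol-1-yl in place of pyrrolidin-1-yl on a saturated chain carbon bound to a triple-bonded carbon). Since the same change gave a 9.8-fold higher number from compound 1 to compound 2 (0.99 log units; beyond the scatter), the expected step in this assay is a step that the limit leaves unreadable from compound 3 to compound 4, an unfavourable shift on top of a starting point that is itself only a limit. Compound 4 is therefore estimated at 100 mg/kg, with a range from 30 mg/kg to 300 mg/kg, and a limit rather than a number is the likelier outcome.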

Compound 4, dose for half-maximal effect: 97 mg/kg
For compound 4 the middle estimate is 1.0-fold (0.01 log units) above the measured one; the range from low to high includes it.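

In this assay no step from compound 3 to compound 4 can be read, as compound 3 reaches only a limit: the limit of > 30 mg/kg in this assay, at which 1 of the 4 values shown sits.

Still open, going by these compounds, is whether 1H-imidazol-1-yl in place of pyrrolidin-1-yl shifts the number as far on the core of compound 3 as on the core of compound 1.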